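This account rests on a few compounds, and the source may have more. Where it says the series, first, only, none or still open, it means among the compounds named here.

Compound 2, with the structure `O=C(/C=C/c1cc2ccccc2[nH]c1=O)c1ccc(O)cc1`, is the starting point of this step. In an ADME assay on OVCAR-8 cells (Homo sapiens) for cytotoxicity, read by sulforhodamine B assay, with a stated time of 24 h (a higher number here means that more compound is tolerated, a lower number that less compound is tolerated), compound 2 gives > 100000 nM, and this figure is a limit of the assay rather than a measured number. The related compound 1, with the structure `COc1ccc(C(=O)/C=C/c2cc3ccccc3[nH]c2=O)cc1`, in this assay gives > 100000 nM, again only a limit. Among the compounds with values here, the one measured step, from compound 1 to compound 2, is therefore a step that the two limits leave unreadable from compound 1 to compound 2, and its size cannot be read; what can be said is that (the limit of > 100000 nM in this assay, at which 2 of the 2 values shown sit).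

Compound 3, with the structure `O=C(/C=C/c1cc2ccccc2[nH]c1=O)c1ccc(Cl)cc1`, is not yet measured. It differs from compound 2 by chloro in place of hydroxy on an aromatic carbon. Within the data shown here, no measured step involves a chloro group, and the only step on record, from compound 1 to compound 2, is a step that the two limits leave unreadable from compound 1 to compound 2 with no readable size, so nothing measured sets a direction for this change. With both known values sitting at the limit, compound 3 is expected to be tolerated to a similar extent, and the expected step from compound 2 to compound 3 is a step that the limit leaves unreadable from compound 2 to compound 3. For compound 3 in this assay the estimate is 150000 nM, within an expected range from 40000 nM to 500000 nM.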

Compound 3, concentration lethal to 50% of the cells: 88400 nM
Compound 3: middle estimate off by 1.7-fold (0.23 log units), on the high side, and the stated range covers the measured number.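

In this assay, compound 3 is the only compound shown that gives a number, while the others sit at a limit: the limit of > 100000 nM in this assay, at which 2 of the 3 values shown sit. Chloro in place of hydroxy gives an at least 1.1-fold lower number from compound 2 to compound 3 (0.05 log units; that floor lies within the scatter), and chloro in place of methoxy gives an at least 1.1-fold lower number from compound 1 to compound 3 (0.05 log units; that floor lies within the scatter). Within the data shown here, each step is only a floor, and neither floor clears the usual scatter, so the result does not establish a real drop; it shows only that a compound with a change at this place on the ring can give a number in this assay.

Among these compounds, with only one measured number, the true size of both steps remains open, as does whether chloro differs in any real way from hydroxy or methoxy here. Also open, on these data alone, is what an amine, a carboxylic acid or a bromo group at this same place would give in this assay.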